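The source may report more compounds than this note shows. Statements on the series, on what has been measured and on what is new or still open speak of the compounds shown alone.

Series notes, antiproliferative readout in a functional assay on MCF7 cells (Homo sapiens) for antiproliferative activity, read by MTT assay, with a stated time of 48 h; a lower number here means a stronger inhibitor, a higher number a weaker inhibitor.

Compound 1 `COc1ccc(-c2nnc(NC(=O)/C=C/c3ccc(C)cc3)s2)cc1` gives 0.31 ug/mL. Compound 2 `Cc1ccc(/C=C/C(=O)Nc2nnc(-c3ccc(Br)cc3)s2)cc1` gives 1.32 ug/mL. Compound 3 `COc1ccc(/C=C/C(=O)Nc2nnc(-c3ccc(OC)cc3)s2)cc1` gives 0.28 ug/mL. Compound 4 `COc1ccc(/C=C/C(=O)Nc2nnc(-c3ccc(Br)cc3)s2)cc1` is not yet measured in this assay.

Compound 3 and compound 1 share the same core except for the difference (methoxy in place of methyl on an aromatic carbon); in this assay that step reads a 1.1-fold lower number from compound 1 to compound 3 (0.04 log units; within the scatter), so the two sit together within the scatter.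

The change from compound 1 to compound 2, (bromo in place of methoxy on an aromatic carbon), gave a 4.3-fold higher number from compound 1 to compound 2 (0.63 log units; beyond the scatter). The change from compound 3 to compound 4 is bromo in place of methoxy on an aromatic carbon, and the two changes are the same, the place lines agreeing word for word. The same kind of change therefore repeats on a core that carries methoxy rather than methyl on the other ring.

Among the compounds with values here, with only one earlier instance of this change, the expectation for compound 4 rests on it: a step of about a 4.3-fold higher number from compound 3 to compound 4 (0.63 log units; beyond the scatter) is expected, since compound 1 to compound 2 gave a 4.3-fold higher number from compound 1 to compound 2 (0.63 log units; beyond the scatter) and compound 3 stands at 0.28 ug/mL. Compound 4 is estimated at 1.2 ug/mL, with a range of 0.5 ug/mL to 3 ug/mL, pending measurement.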

Compound 4, half-maximal inhibitory concentration: 1.13 ug/mL
Compound 4: middle estimate off by 1.1-fold (0.03 log units), on the high side; low and high end bracket the measured number.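

In this assay, bromo in place of methoxy on an aromatic carbon gives a 4.0-fold higher number from compound 3 to compound 4 (0.61 log units; beyond the scatter), so the step seen on the core of compound 1 carries over to the core of compound 3: the same change on two cores in this assay, a 4.3-fold higher number (0.63 log units; beyond the scatter) from compound 1 to compound 2 and a 4.0-fold higher number (0.61 log units; beyond the scatter) from compound 3 to compound 4, 1.1-fold (0.02 log units) apart, within the scatter of two such steps

The other change in the square, methoxy in place of methyl on an aromatic carbon, reads a 1.2-fold lower number from compound 2 to compound 4 (0.07 log units; within the scatter) and again stays within the scatter: the same change on two cores in this assay, a 1.1-fold lower number (0.04 log units; within the scatter) from compound 1 to compound 3 and a 1.2-fold lower number (0.07 log units; within the scatter) from compound 2 to compound 4, 1.1-fold (0.02 log units) apart, within the scatter of two such steps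

This shows that, across these four compounds, each change has about the same size on both cores, but it rests on one pair of steps per change in a single cell assay, so it does not show that the steps would carry to other cores or other read-outs, nor does it explain why the bromo step raises the number.

Still open, as far as these compounds go, is whether other groups at that aromatic carbon, such as an amine, a carboxylic acid or a longer alkoxy chain, would follow the same pattern. Also open, from the compounds shown here alone, is whether any change away from these two aromatic positions would carry from core to core in the same way.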